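Triaryl-methane series: estimating compound 3 in the THP-1 assay

The source may report more compounds than this note shows. Statements on the series, on what has been measured and on what is new or still open speak of the compounds shown alone.

Measured compounds:
compound 1 `COc1ccc(C(OCc2ccccc2)c2cccc3ccccc23)c(OC)c1OC` — > 20000 nM in a functional assay on THP-1 cells (Homo sapiens) for inhibition, read by sulforhodamine B assay, with a stated time of 48 h; a lower number here means a stronger inhibitor, a higher number a weaker inhibitor
compound 2 `C=CCOC(c1ccc(OC)c(OC)c1OC)c1cccc2ccccc12` — > 20000 nM in this assay

Both numbers are limits of this assay, not values. Compound 1 gives only the limit > 20000 nM. Going by the values given here, compound 2 likewise gives only the limit > 20000 nM, so compound 2 stands at the ceiling of what has been read; the one step recorded, a step that the two limits leave unreadable from compound 1 to compound 2, cannot be sized because of the limit of > 20000 nM in this assay, at which 2 of the 2 values shown sit.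

Compound 3 `COc1ccc(C(c2ccc(OCC(=O)O)cc2)c2cccc3ccccc23)c(OC)c1OC` differs from compound 2 in one place: 4-(carboxymethoxy)phenyl in place of allyloxy on a saturated chain carbon bound to two aromatic carbons. Among the compounds with values here, no measured step touches this kind of change, and the single recorded step is unreadable, so no direction can be drawn from the data. With both neighbours at the limit, the step from compound 2 to compound 3 is expected to be a step that the limit leaves unreadable from compound 2 to compound 3, and compound 3 is estimated at 30000 nM in this assay, within a range of 5000 nM to 150000 nM, with a high chance that only a limit is returned again.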

Compound 3, half-maximal inhibitory concentration: > 20000 nM
Compound 3 ended at the assay's limit; the forecaster's own chance of this, stated with the estimate: 70%; the middle value does not contradict the limit.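

No step from compound 1 or compound 2 to compound 3 can be read, because all three compounds stand at the same limit: the limit of > 20000 nM in this assay, at which 3 of the 3 values shown sit.

The compounds shown leave open whether any change on the saturated chain carbon bound to two aromatic carbons gives a readable value in this assay.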